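This account rests on a few compounds, and the source may have more. Where it says the series, first, only, none or still open, it means among the compounds named here.

In a functional assay on A549 cells (Homo sapiens) for antiproliferative activity, read by MTT assay, with a stated time of 72 h (a lower number here means a stronger inhibitor, a higher number a weaker inhibitor), compound 1 `COc1cc(C(=O)c2sc3ccccc3c2-c2ccccc2)cc(OC)c1OC` gives 5000 nM. Compound 2 `COc1ccc(-c2c(C(=O)c3cc(OC)c(OC)c(OC)c3)sc3ccccc23)cc1C` gives > 10000 nM, which is a limit and not a number. Compound 2 therefore stands at the limit of > 10000 nM in this assay, at which 1 of the 2 values shown sits.

Compound 3 `COc1cc(C(=O)c2sc3ccccc3c2Nc2ccc(Cl)cc2)cc(OC)c1OC` carries (4-chlorophenyl)amino in place of 4-methoxy-3-methylphenyl on an aromatic carbon of a five-membered aromatic ring with 1 sulfur: (4-chlorophenyl)amino in place of 4-methoxy-3-methylphenyl on an aromatic carbon. Within the data shown here, the only measured step bearing on this change is an at least 2.0-fold higher number from compound 1 to compound 2 (0.30 log units; that floor lies within the scatter), where 4-methoxy-3-methylphenyl replaced phenyl on an aromatic carbon. Among the measured compounds shown here, no measured compound carries (4-chlorophenyl)amino, so the direction rests on weak ground. With compound 1 at 5000 nM as the one numerical anchor, a modest move to a lower number in this assay is expected. A reading at the limit remains possible for compound 3. The estimated step is an at least 3.3-fold lower number from compound 2 to compound 3 (0.52 log units; beyond the scatter). For compound 3 the estimated value is 3000 nM, with an expected range of 500 nM to 10000 nM.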

Compound 3, half-maximal inhibitory concentration: 3100 nM
The estimate for compound 3 lay 1.0-fold (0.01 log units) below the measured number, within the range that was stated.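

In this assay, among these compounds, the change from 4-methoxy-3-methylphenyl to (4-chlorophenyl)amino gives an at least 3.2-fold lower number from compound 2 to compound 3 (0.50 log units; beyond the scatter), the first step at this aromatic carbon that is printed as lying beyond the scatter, and its size is only a floor. Against the unsubstituted phenyl the same group gives a 1.6-fold lower number from compound 1 to compound 3 (0.21 log units; within the scatter), so at this carbon an aryl ring attached through an amino link reads the same as a directly attached phenyl, and the series keeps its activity with the new linkage. Compound 2 has only a limit and not a number: the limit of > 10000 nM in this assay, at which 1 of the 3 values shown sits.

As far as these compounds go, whether the amino link or the chlorine carries the step remains open; phenylamino without the chlorine and 4-chlorophenyl attached directly to the carbon would separate the two. Also open, from the compounds shown here alone, is how a saturated amine such as morpholine, or a carboxylic acid, would read at this carbon.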